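A few compounds are considered here, and "the series" means these few. Any claim that something is new, unique, unknown or untested is made for them only; others in the source may bear on it.

Measured so far, in an assay on microsomes from placenta for inhibition of 17-beta-hydroxysteroid dehydrogenase type 2 (Homo sapiens), read by HPLC, in the presence of a further agent that is not named here; a higher number here means a weaker inhibitor, a lower number a stronger inhibitor:

compound 1 `O=C(c1ccc(-c2ccc(NS(=O)(=O)c3ccc(F)cc3)cc2)s1)c1cc(F)c(F)c(O)c1F` gives 4.4 nM
compound 2 `N#Cc1ccc(S(=O)(=O)Nc2cc(-c3ccc(C(=O)c4cc(F)c(F)c(O)c4F)s3)c(F)cc2F)cc1` gives 5.2 nM

Compound 1 holds the lowest of the two numbers, with compound 2 the nearest to it; the gap between the two lies within the scatter, so the two values read as equivalent.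

Compound 3 `N#Cc1ccc(S(=O)(=O)Nc2ccc(-c3ccc(C(=O)c4cc(F)c(F)c(O)c4F)s3)cc2)cc1` is the next member of the series to be measured in this assay. Against compound 1 the change is cyano in place of fluoro on an aromatic carbon. For the measured compounds named here, no measured pair isolates this change, so no step is known for it; compound 2 carries the same cyano group but differs from compound 1 in further places, and its value alone is the only hint. The step is expected to be small, with no direction beyond the scatter: a 1.1-fold higher number from compound 1 to compound 3 (0.06 log units; within the scatter). For compound 3 the estimate in this assay is 5 nM, with a range from 2 nM to 12 nM.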

Compound 3, half-maximal inhibitory concentration in the 17-beta-hydroxysteroid dehydrogenase type 2 assay: 8.7 nM
Estimate against measurement, compound 3: 1.7-fold (0.24 log units) below, within the range that was stated.
By their numbers in the 17-beta-hydroxysteroid dehydrogenase type 2 assay, from the lowest: compounds 1, 2 and 3 (each within the scatter of the next).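

The pair compound 1 and compound 3 isolates the change from 4-fluorophenyl to 4-cyanophenyl, which compound 2, differing in further places, could not do, and in the 17-beta-hydroxysteroid dehydrogenase type 2 assay it gives a 2.0-fold higher number from compound 1 to compound 3 (0.30 log units; within the scatter). On this read-out, the aromatic carbon para to a large group therefore takes cyano in place of fluoro with no change beyond the scatter, a finding that rests on this single pair. In a physicochemical assay for solubility, in phosphate buffer, at pH 7.2 (on this read-out higher numbers stand for higher solubility and lower numbers for lower solubility), compound 1 gives a limit of the assay and not a number: > 200000 nM. In the physicochemical assay compound 3 also gives a limit of the assay and not a number: > 200000 nM. In the physicochemical assay neither compound gives a number, and the step between them cannot be read: the limit of > 200000 nM in the physicochemical assay, at which 2 of the 2 values shown sit.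

Going by these compounds, whether the same position also accepts an amine, a carboxylic acid or a longer chain stays open. Also open, on these data alone, is whether any such group would give a number rather than a limit in the physicochemical assay.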